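The compounds below may be only part of what the source reports. "The series", "measured", "known", "first", "only" and "open" are said of these compounds alone.

Measured compounds:

Compound 1 `CCCCCCCCCCCCNC(=O)[C@@H](NC(=O)c1ccccc1)[C@@H](C)O` — in a functional assay on HepG2 cells (Homo sapiens) for cytotoxicity, read by MTT assay, with a stated time of 48 h (a higher number here means a weaker inhibitor, a lower number a stronger inhibitor), compound 1 gives > 400000 nM, which is a limit of the assay and not a number.
Compound 2 `CCCCCCCCCCCCNC(=O)[C@@H](NC(=O)c1cccs1)[C@@H](C)O` — compound 2 gives 30100 nM.
Compound 3 `CCCCCCCCCCCCNC(=O)[C@@H](NC(=O)c1cc2ccccc2o1)[C@@H](C)O` — compound 3 gives 22900 nM.

Compound 3 has the lowest of the two numbers shown, but its nearest neighbour, compound 2, sits within the usual scatter of it, as the step of a 1.3-fold lower number from compound 2 to compound 3 (0.12 log units; within the scatter) shows, so the two cannot be ordered. Compound 4 `CCCCCCCCCCCCNC(=O)[C@@H](NC(=O)c1cc2ccccc2n1C)[C@@H](C)O` differs from compound 3 in one place: 1-methyl-1H-indol-2-yl in place of 1-benzofuran-2-yl on a carbonyl carbon. Among the compounds with values here, two measured steps bear on this change. Replacing phenyl by a heteroaromatic ring on that carbonyl carbon gave the large steps of an at least 13-fold lower number from compound 1 to compound 2 (1.12 log units; beyond the scatter) and an at least 17-fold lower number from compound 1 to compound 3 (1.24 log units; beyond the scatter). Exchanging one such ring for another, however, gave only a 1.3-fold lower number from compound 2 to compound 3 (0.12 log units; within the scatter), which lies within the scatter. Since compound 4 keeps a heteroaromatic bicyclic ring of the same size and shape at the same place, the step from compound 3 to compound 4 is expected to be a 1.1-fold lower number from compound 3 to compound 4 (0.06 log units; within the scatter), that is, nothing beyond the scatter. Compound 4 is therefore estimated at 20000 nM, with a likely range from 7000 nM to 60000 nM.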

Compound 4, half-maximal inhibitory concentration: > 200000 nM
Compound 4: a limit, no number; the forecaster's own chance of this, stated with the estimate: 5%; middle value at least 10-fold (1.00 log units) from the limit.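

Compound 4 gives no number in this assay, only a limit: the limit of > 200000 nM in this assay, at which 1 of the 4 values shown sits.

Even so, the exchange on the carbonyl carbon is not a quiet one: the 1-methyl-1H-indol-2-yl group gives an at least 8.7-fold higher number from compound 3 to compound 4 (0.94 log units; beyond the scatter) and an at least 6.6-fold higher number from compound 2 to compound 4 (0.82 log units; beyond the scatter). Compound 4 thus goes against the lower numbers seen with the heteroaromatic rings of compound 2 and compound 3, so a heteroaromatic ring at this place does not by itself bring a lower number. Compound 1 and compound 4 both stand as limits, so the step between them cannot be read.

From the compounds shown here alone, what stays open is whether the ring nitrogen or its methyl group goes with this change, and an unmethylated 1H-indol-2-yl group would separate the two. Going by these compounds, the true value of compound 4 also remains unknown.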